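Aryl variation on the aromatic nitrogen: compound 3

A few compounds are considered here, and "the series" means these few. Any claim that something is new, unique, unknown or untested is made for them only; others in the source may bear on it.

Compound 1 `N#CC1=C(N)Oc2c(N)cc3nc4ccccc4nc3c2C12C(=O)N(Cc1cnnn1-c1cccc(C(F)(F)F)c1)c1ccccc12` gives 31600 nM in a functional assay on MCF7 cells (Homo sapiens) for antiproliferative activity, read by MTT assay, with a stated time of 48 h; on this read-out lower numbers stand for stronger inhibition and higher numbers for weaker inhibition. Compound 2 `COc1ccccc1-n1nncc1CN1C(=O)C2(C(C#N)=C(N)Oc3c(N)cc4nc5ccccc5nc4c32)c2ccccc21` gives 28900 nM in this assay, and the step of a 1.1-fold lower number from compound 1 to compound 2 (0.04 log units; within the scatter) leaves compound 2 at the lower of the two numbers, though compound 1 lies within the scatter of it. Compound 3 `Cc1cc(C)cc(-n2nncc2CN2C(=O)C3(C(C#N)=C(N)Oc4c(N)cc5nc6ccccc6nc5c43)c3ccccc32)c1` carries 3,5-dimethylphenyl in place of 2-methoxyphenyl on an aromatic nitrogen. Among the compounds with values here, only that single step bears on this change, another aryl swap at the same aromatic nitrogen, and it stayed within the scatter; no step beyond the scatter is therefore expected in this assay for compound 3. Compound 3 is estimated at 28000 nM, range 10000 nM to 80000 nM, an expected step of a 1.0-fold lower number from compound 2 to compound 3 (0.01 log units; within the scatter).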

Compound 3, half-maximal inhibitory concentration: > 50000 nM
Compound 3: no number, only a limit (the forecaster's own chance of this, stated with the estimate: 10%); middle value at least 1.7-fold (0.25 log units) from the limit.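

Within the data shown here, compound 3 gives a limit and not a number, the first such reading at this aromatic nitrogen: the limit of > 50000 nM in this assay, at which 1 of the 3 values shown sits. Only floors can be read for the change to 3,5-dimethylphenyl (an at least 1.7-fold higher number from compound 2 to compound 3 (0.23 log units; that floor lies within the scatter); an at least 1.5-fold higher number from compound 1 to compound 3 (0.19 log units; that floor lies within the scatter)). Both lie within the scatter, so this change is not shown to separate compound 3 from compound 1 or compound 2, although it is the first aryl swap here without a measured number.

As far as these compounds go, the true size of either step remains open. Also open, from the compounds shown here alone, is what a benzyl group, a pyridyl ring or a plain methyl would give on this aromatic nitrogen.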